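Saturating the amide side chain of compound 2

This account rests on a few compounds, and the source may have more. Where it says the series, first, only, none or still open, it means among the compounds named here.

Two measured compounds share a core and differ only in the acyl group on the amide nitrogen. Compound 1 `C/C=C/C(=O)N(Cc1ccc(OC)c([N+](=O)[O-])c1)c1cc(OC)c(OC)c(OC)c1` carries a nitro-substituted benzyl group and a crotonyl amide; in a functional assay on HCT-116 cells (Homo sapiens) for inhibition, read by MTT assay, with a stated time of 48 h (on this read-out lower numbers stand for stronger inhibition and higher numbers for weaker inhibition), compound 1 gives 670 nM. Compound 2 `COc1ccc(CN(C(=O)C=C(C)C)c2cc(OC)c(OC)c(OC)c2)cc1O` carries a hydroxy-substituted benzyl group and a branched unsaturated amide; in this assay compound 2 gives 290 nM, the lowest of the two numbers, with compound 1 standing higher by a margin beyond the usual scatter.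

Compound 3 `COc1ccc(CN(C(=O)C(C)C)c2cc(OC)c(OC)c(OC)c2)cc1O` has not yet been measured. It differs from compound 2 in one place: isopropyl in place of 2-methylprop-1-en-1-yl on a carbonyl carbon. For the measured compounds named here, no measured pair shows this change, so its size is uncertain. The step is expected to read a 3.1-fold higher number from compound 2 to compound 3 (0.49 log units; beyond the scatter), a rise beyond the scatter. Compound 3 is therefore estimated at 900 nM, within a range from 300 nM to 3000 nM.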

Compound 3, half-maximal inhibitory concentration: 310 nM
For compound 3 the middle estimate is 2.9-fold (0.46 log units) above the measured one; low and high end bracket the measured number.
By their numbers in this assay, from the lowest: compounds 2 and 3 (each within the scatter of the next); then compound 1.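

In this assay, the exchange of 2-methylprop-1-en-1-yl for isopropyl on a carbonyl carbon reads as a 1.1-fold higher number from compound 2 to compound 3 (0.03 log units; within the scatter), so the double bond in this side chain can be lost without a difference this read-out can separate from the scatter. For the compounds shown here, compound 1 and compound 2 differ in more than one place, so this pair is the first to isolate the acyl group on the amide nitrogen with the rest of the molecule held constant. Nothing at hand gives a reason for this reading.

Going by these compounds, what a cyclopropyl ring, a tert-butyl group or a longer chain would read on this carbonyl carbon remains open. So does whether the same exchange would read alike with the nitro-substituted benzyl group of compound 1 in place of the hydroxy-substituted one.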